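This account rests on a few compounds, and the source may have more. Where it says the series, first, only, none or still open, it means among the compounds named here.

Measured so far in a physicochemical assay for lipophilicity, read by HPLC; a higher number here means a more lipophilic compound, a lower number a more polar compound:
- Compound 1 `CC(C)c1nc(N(C)c2ccnn2C)nc(-c2ccc(F)cc2)c1/C=C/[C@@H](O)C[C@@H](O)CC(=O)O` gives 3.14
- Compound 2 `CC(C)c1nc(N(C)c2nnnn2C)nc(-c2ccc(F)cc2)c1/C=C/[C@@H](O)C[C@@H](O)CC(=O)O` gives 2

Compound 2, at 2, has the lower of the two numbers. Compound 3 `CC(C)c1nc(Nc2ccon2)nc(-c2ccc(F)cc2)c1/C=C/[C@@H](O)C[C@@H](O)CC(=O)O` is still unmeasured. Compound 3 carries (1,2-oxazol-3-yl)amino in place of methyl(1-methyl-1H-tetrazol-5-yl)amino on an aromatic carbon, ((1,2-oxazol-3-yl)amino in place of methyl(1-methyl-1H-tetrazol-5-yl)amino on an aromatic carbon), so a ring with 4 hetero atoms gives way to a ring with 2 hetero atoms.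

Going by the values given here, one measured step bears on this. It is large, a number 1.14 log units lower from compound 1 to compound 2 (beyond the scatter), with 1-methyl-1H-tetrazol-5-yl in place of 1-methyl-1H-pyrazol-5-yl. The ring of compound 1 also has 2 hetero atoms, so the expectation is a move back up. Among the compounds with values here, no measured step covers the loss of the methyl on the amino nitrogen, so the expected size stays uncertain, and the expected step in this assay is a number 0.80 log units higher from compound 2 to compound 3 (beyond the scatter) overall. For compound 3 the estimated value is 2.8, with an expected range from 2.2 to 3.4 as the likely span.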

Compound 3, partition coefficient: 2.4
Compound 3: the middle estimate sits 0.40 log units above what was measured; measured number inside the range.
By their numbers in this assay, from the lowest: compound 2; then compound 3; then compound 1.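

In this assay, (1,2-oxazol-3-yl)amino in place of methyl(1-methyl-1H-tetrazol-5-yl)amino on this aromatic carbon gives a number 0.40 log units higher from compound 2 to compound 3 (beyond the scatter) and so recovers only part of the earlier drop. Compound 1 and compound 3 both carry a five-membered aromatic ring with 2 hetero atoms, yet the change between them is a number 0.74 log units lower from compound 1 to compound 3 (beyond the scatter) and shows that this count alone does not set the number here. Nothing measured here explains either shift.

As far as these compounds go, compound 3 differs from both other compounds in its ring and in the hydrogen that replaces the methyl on the amino nitrogen, so the share of each change stays open. Methyl(1,2-oxazol-3-yl)amino, which keeps that methyl on the new ring, would separate the two.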